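Aryl swaps on the shared core: from pyridyl to isothiazolyl

This account rests on a few compounds, and the source may have more. Where it says the series, first, only, none or still open, it means among the compounds named here.

Three analogues of the shared core differ only in the aromatic group on the phenyl ring. Compound 1 `CCC(C)(C)Cc1c[nH]c(CCc2ccc(-c3cccc(C#N)n3)cc2)n1` gives 95 nM in a functional assay on HEK293 cells for agonist activity at Bombesin receptor subtype-3 (Homo sapiens), read by luminescence and calcium flux, with a stated time of 10 min; a higher number here means that more compound is needed for the effect, a lower number that less compound is needed. Compound 2 `CCC(C)(C)Cc1c[nH]c(CCc2ccc(-n3cncn3)cc2)n1` gives 89 nM in this assay, and compound 3 `CCC(C)(C)Cc1c[nH]c(CCc2ccc(-c3cccnc3)cc2)n1` gives 98 nM. All three numbers sit together: the step of a 1.1-fold lower number from compound 1 to compound 2 (0.03 log units; within the scatter), the step of a 1.0-fold higher number from compound 1 to compound 3 (0.01 log units; within the scatter) and the step of a 1.1-fold higher number from compound 2 to compound 3 (0.04 log units; within the scatter) are each within the scatter, so compound 3 cannot be set apart from compound 1 or compound 2 on these numbers.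

The next member, compound 4 `CCC(C)(C)Cc1c[nH]c(CCc2ccc(-c3ccns3)cc2)n1`, differs from compound 3 by 1,2-thiazol-5-yl in place of pyridin-3-yl on an aromatic carbon. For the measured compounds named here, no measured step covers this group, but the three measured swaps of the aryl group, all within the scatter, bear on it. A step beyond the scatter in this assay is therefore not expected in either direction. The step expected is a 1.0-fold lower number from compound 3 to compound 4 (0.01 log units; within the scatter). Compound 4 is estimated at 95 nM, with a range from 45 nM to 200 nM.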

Compound 4, half-maximal effective concentration: 102 nM
Estimate against measurement, compound 4: 1.1-fold (0.03 log units) below; the range from low to high includes it.
By their numbers in this assay, from the lowest: compounds 2, 1, 3 and 4 (each within the scatter of the next).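

In this assay, the five-membered 1,2-thiazol-5-yl, with sulfur in its ring, cannot be told apart from the six-membered pyridin-3-yl (a 1.0-fold higher number from compound 3 to compound 4 (0.02 log units; within the scatter)), from 1H-1,2,4-triazol-1-yl (a 1.1-fold higher number from compound 2 to compound 4 (0.06 log units; within the scatter)) or from 6-cyanopyridin-2-yl (a 1.1-fold higher number from compound 1 to compound 4 (0.03 log units; within the scatter)). The aromatic carbon para to a large group therefore accepts a sulfur-containing aromatic ring as well, with no step beyond the scatter across all four compounds. Nothing at hand explains this flat response.

On these data alone, all four groups are aromatic rings, so it remains open whether an amine, a carboxylic acid or a longer alkyl chain at this place would shift the number beyond the scatter. As far as these compounds go, whether the same flat response holds when the shared core changes elsewhere also remains open.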